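This account rests on a few compounds, and the source may have more. Where it says the series, first, only, none or still open, it means among the compounds named here.

In an ADME assay on HFF cells (Homo sapiens) for cytotoxicity, with a stated time of 8 days (on this read-out higher numbers stand for lower toxicity in this test and lower numbers for higher toxicity in this test), compound 1 `CN(C)c1nc(N)nc2c1ncn2/C=C1/CC1(CO)CO` gives > 300000 nM as a limit of the assay, not a number. Compound 2 `CCCCCCCCSc1nc(N)nc2c1ncn2/C=C1/CC1(CO)CO` gives > 300000 nM as a limit too, so it has no exact value. The record so far is the limit of > 300000 nM in this assay, at which 2 of the 2 values shown sit, and holds no lower reading. Compound 3 `Nc1nc(NC2CCCCC2)c2ncn(/C=C3/CC3(CO)CO)c2n1` carries cyclohexylamino in place of octylsulfanyl on an aromatic carbon, and the change is counted here: cyclohexylamino in place of octylsulfanyl on an aromatic carbon and the rest of the structure stays the same. Among the compounds with values here, the one measured step, a step that the two limits leave unreadable from compound 1 to compound 2, gives no size to carry over. It also changed the group at this same place, and both its ends are limits, so no step beyond the usual scatter is expected in this assay for the new change. The expected step is a number no higher from compound 2 to compound 3 (the limit leaves the size open) on this estimate. For compound 3 the estimated value is 300000 nM with an expected range from 120000 nM to 500000 nM and quite possibly another limit.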

Compound 3, half-maximal cytotoxic concentration: > 300000 nM
Compound 3 gave a limit, no number; the forecaster's own chance of this, stated with the estimate: 75%; the middle value lies on the limit itself.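

No step can be read among compound 1, compound 2 and compound 3 in this assay, and none has an exact value: the limit of > 300000 nM in this assay, at which 3 of the 3 values shown sit.

On these data alone, whether dimethylamino, octylsulfanyl and cyclohexylamino on this aromatic carbon differ at all in toxicity in this test stays open.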